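Aryl Swap on the Acrylamide Arm of a Shared Core

This account rests on a few compounds, and the source may have more. Where it says the series, first, only, none or still open, it means among the compounds named here.

Compound 3 `N#Cc1ccc(/C=C/C(=O)Nc2cc3c(Nc4ccc(F)c(Cl)c4)ncnc3cc2O[C@H]2CCOC2)cc1` carries a 4-cyanophenyl on the double-bonded chain carbon bound to a double-bonded chain carbon of the acrylamide arm. In a functional assay on A549 cells (Homo sapiens) for cytotoxicity, read by MTT assay, with a stated time of 72 h (a higher number here means a weaker inhibitor, a lower number a stronger inhibitor), compound 3 gives "not active" (no number reported), and no single number stands against it. Its two neighbours on the same core do carry numbers: compound 1 `COc1cc(/C=C/C(=O)Nc2cc3c(Nc4ccc(F)c(Cl)c4)ncnc3cc2O[C@H]2CCOC2)cc(OC)c1` gives 10800 nM in this assay, and compound 2 `O=C(/C=C/c1cc(Br)c(O)c(Br)c1)Nc1cc2c(Nc3ccc(F)c(Cl)c3)ncnc2cc1O[C@H]1CCOC1` gives 28800 nM. Going by the values given here, the one measured step, a 2.7-fold higher number from compound 1 to compound 2 (0.43 log units; beyond the scatter), also exchanges the aryl group at this place, and it moved the number only modestly. Compound 4 `O=C(/C=C/c1ccccc1[N+](=O)[O-])Nc1cc2c(Nc3ccc(F)c(Cl)c3)ncnc2cc1O[C@H]1CCOC1` differs from compound 3 as follows: 2-nitrophenyl in place of 4-cyanophenyl on a double-bonded chain carbon bound to a double-bonded chain carbon. Among the compounds with values here, no measured step covers this exchange directly, so the one step that bears on it is the aryl swap from compound 1 to compound 2, which was of modest size. Given that compound 3 returned no number in this assay and that the two aryl analogues with numbers sit far up the scale, compound 4 is expected to remain a weak inhibitor, most likely again without a reportable number. The estimated value of compound 4 in this assay is 40000 nM, with a range from 10000 nM to 150000 nM.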

Compound 4, half-maximal inhibitory concentration: 8820 nM
Beside the measured number, compound 4's estimate is 4.5-fold (0.66 log units) above it; measured number outside the range, below it.
By their numbers in this assay, from the lowest: compounds 4 and 1 (each within the scatter of the next); then compound 2.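

In this assay, going by these compounds alone, compound 4 gives 8820 nM where compound 3 returned no number, so at this place, on a double-bonded chain carbon bound to a double-bonded chain carbon, a 2-nitrophenyl keeps a measurable result that the 4-cyanophenyl did not give, though no step from compound 3 can be read. The new steps are a 3.3-fold lower number from compound 2 to compound 4 (0.51 log units; beyond the scatter) and a 1.2-fold lower number from compound 1 to compound 4 (0.09 log units; within the scatter) and so the 2-nitrophenyl and 3,5-dimethoxyphenyl groups cannot be told apart in this read-out, while the 3,5-dibromo-4-hydroxyphenyl of compound 2 carries the highest number of the three compounds with values. Nothing measured here explains why compound 3 gave no number while its aryl neighbours gave values.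

The exchange from compound 3 to compound 4 alters both the group on the ring and where it sits, so the compounds shown do not separate these two changes. They also leave open how this place would respond to an unsubstituted phenyl, or to a phenyl carrying an amine or a carboxylic acid, and whether any aryl group here can bring the number far down the scale.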